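The source may report more compounds than this note shows. Statements on the series, on what has been measured and on what is new or still open speak of the compounds shown alone.

Working notes on the series. Compound 2 `Nc1ncccc1-c1nc2cccnc2n1-c1ccc(CNC(=O)C2CCCCC2)cc1` reaches 5.7 degrees C in an in vitro assay on Sf9 cells for binding affinity to RAC-alpha serine/threonine-protein kinase (Homo sapiens), tested at 30 uM (on this read-out lower numbers stand for weaker stabilisation of the target and higher numbers for stronger stabilisation of the target against heat), and stands second highest of the three numbers: compound 3 `Nc1ncccc1-c1nc2cc(-c3cccnc3)cnc2n1-c1ccc(CNC(=O)c2ccccc2)cc1` lies nearest at 9.2 degrees C (beyond the scatter), compound 1 `CC(C)(C)c1ccc(-n2c(-c3cccnc3N)nc3cccnc32)cc1` furthest at 1.9 degrees C (beyond the scatter). Among the compounds with values here, the only step touching this position is a number 3.8 degrees C higher from compound 1 to compound 2 (beyond the scatter), a modest gain. Compound 4 `CC(=O)Nc1ccc(-n2c(-c3cccnc3N)nc3cccnc32)cc1` carries the change (acetamido in place of ((cyclohexylcarbonyl)amino)methyl on an aromatic carbon), on an aromatic carbon para to a large group. The amide donor and acceptor stay; the ring and the linking carbon leave, which takes compound 4 part of the way back toward compound 1. A drop beyond the scatter is therefore expected, estimated as a number 2.2 degrees C lower from compound 2 to compound 4 (beyond the scatter). Compound 4 is expected near 3.5 degrees C in this assay, within a range of 1.5 degrees C to 5.5 degrees C.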

Compound 4, shift of the target's melting temperature: 3.7 degrees C
Compound 4: the middle estimate sits 0.20 degrees C below what was measured, within the range that was stated.
By their numbers in this assay, from the lowest: compound 1; then compound 4; then compound 2; then compound 3.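

In this assay this position on the aromatic carbon now shows a graded order of three groups. Acetamido still improves on tert-butyl, with a number 1.8 degrees C higher from compound 1 to compound 4 (beyond the scatter), but does not match ((cyclohexylcarbonyl)amino)methyl, with a number 2.0 degrees C lower from compound 2 to compound 4 (beyond the scatter). Nothing measured here accounts for this order. The shown compounds leave open whether the difference between these two amide groups follows the cyclohexane ring or the linking carbon, since both change together. An acetamidomethyl group or a cyclohexanecarboxamido group at this position would separate the two.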